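Amine swap on the compound 3 side chain

The source may hold more compounds than are shown below. What is called first, only, known or untested is meant among the compounds shown, and "the series" means these compounds.

Values measured in an in vivo ADME assay on the whole organism for pharmacokinetics, with Canis familiaris (Canis lupus familiaris) as the target (on this read-out higher numbers stand for higher oral bioavailability and lower numbers for lower oral bioavailability), are as follows
- compound 1 `CN(C)Cc1ccccc1-c1ccc(N2CCc3c(C(F)(F)F)nn(-c4ccc5onc(N)c5c4)c3C2=O)c(F)c1`: 83%
- compound 2 `Cc1nn(-c2ccc3onc(N)c3c2)c2c1CCN(c1ccc(-c3ccccc3CN3CCCC3)cc1)C2=O`: 10%
- compound 3 `Nc1noc2ccc(-n3nc(C(F)(F)F)c4c3C(=O)N(c3ccc(-c5ccccc5CN5CCCC5)cc3)CC4)cc12`: 37%

Of these three, compound 3 at 37% is the second highest, above compound 2 and below compound 1.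

Compound 4 `CNCc1ccccc1-c1ccc(N2CCc3c(C(F)(F)F)nn(-c4ccc5onc(N)c5c4)c3C2=O)cc1` has not been measured. Its difference from compound 3 is methylamino in place of pyrrolidin-1-yl on a saturated chain carbon bound to an aromatic carbon or, in words, methylamino in place of pyrrolidin-1-yl on a saturated chain carbon bound to an aromatic carbon.

For the measured compounds named here, the only measured step is a number 27 percentage points higher from compound 2 to compound 3 (beyond the scatter) and it is a different change: trifluoromethyl in place of methyl on an aromatic carbon. It does not touch the pyrrolidin-1-yl group, so it gives no direct size for this step. Compound 1 also lacks pyrrolidin-1-yl and reaches 83% but differs from compound 3 in more than one place, so no step can be read from that pair. The wide spread of the three values still argues for a broad range.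

No step beyond the scatter is expected, and the estimate is a number 5 percentage points higher from compound 3 to compound 4 (within the scatter) with only weak support for its direction. In this assay the estimate for compound 4 is 42% with an expected range from 18% to 66% for now.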

Compound 4, oral bioavailability: 67%
Estimate against measurement, compound 4: 25 percentage points below; measured number outside the range, above it.
By their numbers in this assay, from the lowest: compound 2; then compound 3; then compound 4; then compound 1.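

Swapping pyrrolidin-1-yl for methylamino on a saturated chain carbon bound to an aromatic carbon gives, in this assay, a number 30 percentage points higher from compound 3 to compound 4 (beyond the scatter), with the rest of the structure unchanged. The earlier single-place step, a number 27 percentage points higher from compound 2 to compound 3 (beyond the scatter), concerned trifluoromethyl in place of methyl on an aromatic carbon, so the side-chain amine is now a second place in the series where one change moves oral bioavailability beyond the scatter. This change both removes the five-membered ring and adds a hydrogen-bond donor, and no measurement shown bears on what lies behind the rise.

The compounds shown do not separate loss of the ring from gain of the donor, and the dimethylamino side chain of compound 1 cannot settle this, as compound 1 differs from compound 4 in more than one place. An unsubstituted amino group, an ethylamino group or a morpholine ring at the same place on the core of compound 4 would show whether the number tracks the ring, the donor or the size of the amine.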